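The compounds below may be only part of what the source reports. "The series", "measured", "known", "first", "only" and "open" are said of these compounds alone.

Measured so far:
Compound 1, `COc1cc(OC)c(-c2coc3cc(OCC=C(C)C)ccc3c2=O)cc1OC`: 1580 nM
Compound 2, `COc1cc(OC)c(-c2coc3cc(OCc4ccccc4)ccc3c2=O)cc1OC`: 1640 nM

In a functional assay on A-375 cells (Homo sapiens) for antiproliferative activity, read by MTT assay, with a stated time of 24 h (a lower number here means a stronger inhibitor, a higher number a weaker inhibitor), compound 2 gives 1640 nM, the higher of the two numbers recorded, though compound 1 sits so close that the two are not separable: the step of a 1.0-fold higher number from compound 1 to compound 2 (0.02 log units; within the scatter) lies within the scatter. Compound 3, `COc1ccc2c(=O)c(-c3cc(OC)c(OC)cc3OC)coc2c1`, has not been measured. It differs from compound 2 by hydrogen in place of phenyl on a saturated chain carbon bound to an oxygen on an aromatic ring, so the benzyloxy of compound 2 becomes a methoxy in compound 3. Among the measured compounds shown here, the only measured step bearing on this position is a 1.0-fold higher number from compound 1 to compound 2 (0.02 log units; within the scatter), which shows that swapping one group for another on that saturated chain carbon changed nothing beyond the scatter. Removing the phenyl altogether is a larger cut than either measured compound covers, so the expected step is small but uncertain; compound 3 is estimated to show a 1.3-fold higher number from compound 2 to compound 3 (0.13 log units; within the scatter), most likely within the scatter, perhaps toward a somewhat higher number. Compound 3 is therefore expected to give about 2200 nM, with a range from 800 nM to 6000 nM.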

Compound 3, half-maximal inhibitory concentration: 2640 nM
Compound 3: middle estimate off by 1.2-fold (0.08 log units), on the low side; low and high end bracket the measured number.
By their numbers in this assay, from the lowest: compounds 1, 2 and 3 (each within the scatter of the next).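

In this assay, the saturated chain carbon bound to an oxygen on an aromatic ring now tolerates more than an exchange of one large group for another, since the group can be removed altogether: hydrogen in place of phenyl gives (a 1.6-fold higher number from compound 2 to compound 3 (0.21 log units; within the scatter)), and hydrogen in place of 2-methylprop-1-en-1-yl gives (a 1.7-fold higher number from compound 1 to compound 3 (0.22 log units; within the scatter)). Both steps lie within the scatter, so going from benzyloxy to methoxy cannot be told apart from no change, and neither phenyl nor 2-methylprop-1-en-1-yl shows a contribution that can be read here. Nothing is available that would explain this result.

On these data alone, whether an amine, a carboxylic acid or a longer chain at this place would move the number beyond the scatter remains open. So does whether a free hydroxyl in place of the methoxy of compound 3 would do so.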